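Compound 4: a new amino group among limits

A few compounds are considered here, and "the series" means these few. Any claim that something is new, unique, unknown or untested is made for them only; others in the source may bear on it.

Compound 3 `CC(=O)c1c(N2CCCCC2)[nH]c2c(F)cc(F)cc2c1=O` is the starting point of this step. In an ADME assay on Vero cells (Chlorocebus sabaeus) for cytotoxicity (on this read-out higher numbers stand for lower toxicity in this test and lower numbers for higher toxicity in this test), compound 3 gives > 25000 nM, which is a limit of the assay and not a number. Two relatives stand in the same position. In this assay compound 1 `CC(=O)c1c(Nc2ccc(F)cc2F)[nH]c2c(F)cc(Cl)cc2c1=O` gives > 25000 nM, which is also a limit. In this assay compound 2 `CC(=O)c1c(Nc2ccc(F)cc2F)[nH]c2c([N+](=O)[O-])cc(Cl)cc2c1=O` gives > 25000 nM, again a limit. The whole picture is therefore (the limit of > 25000 nM in this assay, at which 3 of the 3 values shown sit), and compound 3 cannot be ranked against the other two.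

Compound 4 `CC(=O)c1c(Nc2ccc(Cl)cc2)[nH]c2c(F)cc(F)cc2c1=O` carries (4-chlorophenyl)amino in place of piperidin-1-yl on an aromatic carbon, next to the ring nitrogen and ortho to an acetyl group ((4-chlorophenyl)amino in place of piperidin-1-yl on an aromatic carbon). Among the compounds with values here, the only measured step, a step that the two limits leave unreadable from compound 1 to compound 2, exchanges fluoro for nitro and has no readable size, so it gives no direct measure of this change. Compound 1 does show an aromatic ring on an amino group in that place, and it gives > 25000 nM, a limit. No step beyond the scatter is therefore expected in this assay, and the estimated step is a step that the limit leaves unreadable from compound 3 to compound 4. For compound 4 the estimated value is 30000 nM, with an expected range from 12000 nM to 60000 nM.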

Compound 4, half-maximal cytotoxic concentration: > 25000 nM
Compound 4: no number, only a limit; the forecaster's own chance of this, stated with the estimate: 70%; the middle value does not contradict the limit.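

Compound 3 and compound 4 both stand at a limit in this assay, so no step can be read between them, and the exchange of piperidin-1-yl for (4-chlorophenyl)amino has no readable size. The compounds shown leave open how far each one lies from that limit, and whether any of these changes shifts the read-out at all: the limit of > 25000 nM in this assay, at which 4 of the 4 values shown sit.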